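This account rests on a few compounds, and the source may have more. Where it says the series, first, only, none or still open, it means among the compounds named here.

Measured compounds in a functional assay on DU-145 cells (Homo sapiens) for cytotoxicity, read by CCK-8 assay and cell counting, with a stated time of 2 days; a higher number here means a weaker inhibitor, a lower number a stronger inhibitor:
compound 1 `Oc1ccc(-c2cc(-c3ccc(Cl)cc3)nc(-c3cccnc3)c2)cc1` gives 22800 nM;
compound 2 `Oc1ccc(-c2cc(-c3ccco3)nc(-c3ccccc3Cl)c2)cc1` gives 5300 nM;
compound 3 `Oc1ccc(-c2cc(-c3cccnc3)nc(-c3cccc(Cl)c3)c2)cc1` gives 22900 nM.

Compound 3 gives the highest of the three numbers; compound 1 sits within the scatter of it, while compound 2 lies beyond the scatter at the lower end. Compound 4 `Oc1ccc(-c2cc(-c3cccc(Cl)c3)nc(-c3ccco3)c2)cc1` differs from compound 3 by furan-2-yl in place of pyridin-3-yl on an aromatic carbon. Going by the values given here, the one measured step, a 1.0-fold higher number from compound 1 to compound 3 (0.00 log units; within the scatter), concerns the chlorophenyl group and does not bear on this change. Compound 2 also carries furan-2-yl, though with a different chlorophenyl, and its number is lower than that of compound 3, so a lower number is expected for compound 4, by roughly a 2.9-fold lower number from compound 3 to compound 4 (0.46 log units; beyond the scatter). Compound 4 is therefore estimated at 8000 nM, between 3000 nM and 25000 nM.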

Compound 4, half-maximal inhibitory concentration: 5750 nM
For compound 4 the middle estimate is 1.4-fold (0.14 log units) above the measured one, and the stated range covers the measured number.
By their numbers in this assay, from the lowest: compounds 2 and 4 (each within the scatter of the next); then compounds 1 and 3 (each within the scatter of the next).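

In this assay, going by these compounds alone, furan-2-yl in place of pyridin-3-yl next to the ring nitrogen gives a 4.0-fold lower number from compound 3 to compound 4 (0.60 log units; beyond the scatter), the first direct reading of this change with the 3-chlorophenyl group held fixed. With furan-2-yl present, 3-chlorophenyl in place of 2-chlorophenyl gives a 1.1-fold higher number from compound 2 to compound 4 (0.04 log units; within the scatter), so these two chlorophenyl groups do not separate. No measurement here accounts for the furan-2-yl step. The compounds shown leave open how an amine or a longer alkyl chain at this position would compare with furan-2-yl. They also leave open whether the step holds with 4-chlorophenyl in place of 3-chlorophenyl.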